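Aryl group change on the ring nitrogen: outlook for compound 4

This account rests on a few compounds, and the source may have more. Where it says the series, first, only, none or still open, it means among the compounds named here.

Three measured compounds share one core and differ only in the aryl group on an amine nitrogen in a ring. In a functional assay on CHO cells with adenosine receptor A1 (Homo sapiens) as the target, read by cAMP accumulation and immunoassay, with a stated time of 6 min, tested at 0.01 uM (on this read-out higher numbers stand for a weaker effect at the one concentration tested and lower numbers for a stronger effect), compound 1 `Nc1scc(CN2CCN(c3cccc(Cl)c3Cl)CC2)c1C(=O)c1ccc(Cl)cc1` gives 1%. In this assay compound 2 `Nc1scc(CN2CCN(c3ccc(Cl)c(C(F)(F)F)c3)CC2)c1C(=O)c1ccc(Cl)cc1` gives -2.5%, and compound 3 `Nc1scc(CN2CCN(c3ccc(OC(F)(F)F)cc3)CC2)c1C(=O)c1ccc(Cl)cc1` gives 0%. Compound 3 stands second highest of the three numbers; the nearest is compound 1, with a number 1 percentage points lower from compound 1 to compound 3 (within the scatter), and the furthest is compound 2, with a number 2.5 percentage points higher from compound 2 to compound 3 (within the scatter). The third pair shows a number 3.5 percentage points lower from compound 1 to compound 2 (within the scatter). All three steps lie within the scatter, so the three aryl groups tried so far cannot be told apart on this read-out.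

Compound 4 `Nc1scc(CN2CCN(c3ccc(F)cc3F)CC2)c1C(=O)c1ccc(Cl)cc1` carries the change (2,4-difluorophenyl in place of 4-(trifluoromethoxy)phenyl on an amine nitrogen in a ring). Every measured step bears on it, since each is an aryl exchange at the same ring nitrogen, and none moved the number beyond the scatter. For the measured compounds named here, no measured step involves the 2,4-difluorophenyl group itself. The expected step is therefore no change at the digits printed from compound 3 to compound 4 (within the scatter), none beyond the scatter. For compound 4 the estimate in this assay is 0%, with a range from -10% to 10%.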

Compound 4, a percentage reported as activity, at one concentration (the size of the read-out at that concentration, not a potency): 0%
Compound 4: the middle estimate sits on the measured number at the digits printed; the measured number falls inside the stated range.
By their numbers in this assay, from the lowest: compounds 2, 3, 4 and 1 (each within the scatter of the next).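

In this assay, 2,4-difluorophenyl on the amine nitrogen in a ring gives no change at the digits printed from compound 3 to compound 4 (within the scatter), a number 2.5 percentage points higher from compound 2 to compound 4 (within the scatter) and a number 1 percentage points lower from compound 1 to compound 4 (within the scatter), so a fourth aryl group joins the three that cannot be told apart on this read-out. The exchange at this position extends the flat result to a group of 8 heavy atoms with 0 hydrogen-bond acceptors, against 11 heavy atoms and 1 hydrogen-bond acceptor in 4-(trifluoromethoxy)phenyl. No available evidence bears on why the read-out stays flat across these groups.

As far as these compounds go, it remains open whether a benzyl or acetyl group in place of the aryl group, or an aryl group carrying a carboxylic acid or an amine, would move the number beyond the scatter. From the compounds shown here alone, whether these four compounds would also stay together at other concentrations is equally open.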